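A few compounds are considered here, and "the series" means these few. Any claim that something is new, unique, unknown or untested is made for them only; others in the source may bear on it.

Values so far in a functional assay on MKN-45 cells (Homo sapiens) for antiproliferative activity; a lower number here means a stronger inhibitor, a higher number a weaker inhibitor:
- compound 1 `COc1ccc(S(=O)(=O)N2CCc3cccc(Nc4ccc(O)cc4)c32)cc1`: 493 nM
- compound 2 `COc1ccc(S(=O)(=O)N2CCc3cccc(Nc4ccc(Cl)cc4)c32)cc1`: 463 nM
- compound 3 `COc1ccc(S(=O)(=O)N2CCc3cccc(Nc4ccc([N+](=O)[O-])cc4)c32)cc1`: 107 nM

Compound 3 has the lowest number of the three. The two steps that reach it are both modest and beyond the scatter: a 4.6-fold lower number from compound 1 to compound 3 (0.66 log units; beyond the scatter) and a 4.3-fold lower number from compound 2 to compound 3 (0.64 log units; beyond the scatter). The remaining step, a 1.1-fold lower number from compound 1 to compound 2 (0.03 log units; within the scatter), lies within the scatter, so hydroxy and chloro do not separate in this small set.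

Next is compound 4 `COc1ccc(S(=O)(=O)N2CCc3cccc(Nc4ccc(C#N)cc4)c32)cc1`, with cyano in place of nitro on an aromatic carbon, para to a large group: cyano in place of nitro on an aromatic carbon. The shared core is otherwise unchanged.

Going by the values given here, no measured compound carries cyano, so the evidence is indirect. Only nitro has given a step beyond the scatter, and the data do not show whether cyano would keep that gain. The two steps to compound 3 are modest in size, so the number can reasonably be expected to move only a little, with compound 2 at 463 nM as a guide to a full loss of the gain. A small move toward a higher number in this assay is expected, and the estimated change is a 1.5-fold higher number from compound 3 to compound 4 (0.17 log units; within the scatter). For compound 4 the estimated value is 160 nM, with an expected range of 70 nM to 350 nM.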

Compound 4, half-maximal inhibitory concentration: 92 nM
The estimate for compound 4 lay 1.7-fold (0.24 log units) above the measured number, and the stated range covers the measured number.
By their numbers in this assay, from the lowest: compounds 4 and 3 (each within the scatter of the next); then compounds 2 and 1 (each within the scatter of the next).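

In this assay, the step of a 1.2-fold lower number from compound 3 to compound 4 (0.07 log units; within the scatter) shows that cyano and nitro do not separate on this aromatic carbon, para to a large group, so the low numbers in the series are no longer tied to nitro alone. Cyano also stands clear of both remaining groups, with a 5.0-fold lower number from compound 2 to compound 4 (0.70 log units; beyond the scatter) and a 5.4-fold lower number from compound 1 to compound 4 (0.73 log units; beyond the scatter) as its steps, and the four compounds now fall into two pairs, cyano and nitro at the low end and chloro and hydroxy at the high end, with no compound shown going against that split. Nothing at hand bears on why cyano and nitro fall together or why they part from chloro and hydroxy.

Still open, on these data alone, is where groups such as a carboxylic acid, a primary amide, a methylsulfonyl or a trifluoromethyl would fall at this carbon, and whether any of them would go beyond the level of cyano and nitro. Also open is whether cyano would hold this level on another carbon of the same ring, since every compound shown carries its group at this one place.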